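Cyclohexylsulfanyl analog of compound 3: expected cytotoxicity

The compounds below may be only part of what the source reports. "The series", "measured", "known", "first", "only" and "open" are said of these compounds alone.

Measured so far:
Compound 1 `N#Cc1ccc(Nc2nccc(SC3CCCCC3)n2)cc1` gives > 402000 nM in an ADME assay on MT4 cells (Homo sapiens) for cytotoxicity, read by MTT assay; on this read-out lower numbers stand for higher toxicity in this test and higher numbers for lower toxicity in this test. For compound 1 this value is a limit of this assay and not a number.
Compound 2 `Cc1cnc(Nc2ccc(C#N)cc2)nc1NC1CCCCC1` gives 1300 nM.
Compound 3 `Cc1cnc(Nc2ccc(C#N)cc2)nc1OC1CCCC1` gives 9990 nM.

Among the two numbers, compound 3 stands highest; its nearest neighbour is compound 2, and the step of a 7.7-fold higher number from compound 2 to compound 3 (0.89 log units; beyond the scatter) lies beyond the scatter. Compound 4 `Cc1cnc(Nc2ccc(C#N)cc2)nc1SC1CCCCC1` has not yet been measured. It differs from compound 3 by cyclohexylsulfanyl in place of cyclopentyloxy on an aromatic carbon. For the measured compounds named here, no measured step matches this change: the one step known, from compound 2 to compound 3, exchanges an amino-linked for an oxygen-linked ring and says nothing about a sulfur-linked one. Compound 1, which carries the same cyclohexylsulfanyl group without the methyl, reaches only the limit (the limit of > 402000 nM in this assay, at which 1 of the 3 values shown sits). The expectation for compound 4 therefore leans toward a higher number, with wide uncertainty. For compound 4 the estimate is 40000 nM, ranging from 6000 nM to 400000 nM. The step of a 4.0-fold higher number from compound 3 to compound 4 (0.60 log units; beyond the scatter) is thus expected, upward.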

Compound 4, half-maximal cytotoxic concentration: 33400 nM
Beside the measured number, compound 4's estimate is 1.2-fold (0.08 log units) above it; low and high end bracket the measured number.
By their numbers in this assay, from the lowest: compound 2; then compound 3; then compound 4. At a limit, above all of these: compound 1.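

In this assay, cyclohexylsulfanyl in place of cyclopentyloxy brings a 3.3-fold higher number from compound 3 to compound 4 (0.52 log units; beyond the scatter), while cyclohexylsulfanyl in place of cyclohexylamino, which keeps the six-membered ring and changes only the atom joining it to the core, brings a 26-fold higher number from compound 2 to compound 4 (1.41 log units; beyond the scatter), so that atom alone moves the number at this position. Methyl in place of hydrogen on an aromatic carbon brings an at least 12-fold lower number from compound 1 to compound 4 (1.08 log units; beyond the scatter), which shows that the cyclohexylsulfanyl group does not set the number alone. Compound 1 stands at a limit of this assay and not at a number: the limit of > 402000 nM in this assay, at which 1 of the 4 values shown sits.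

The compounds shown leave open how far ring size and the joining atom each contribute to the step to compound 4, which a cyclohexyloxy or cyclopentylsulfanyl group would separate. As far as these compounds go, how an open-chain group such as a longer alkyl chain would read at this position also remains open.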